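Aryl swap from compound 3 to compound 4

The source may report more compounds than this note shows. Statements on the series, on what has been measured and on what is new or still open speak of the compounds shown alone.

Compound 1 `COc1cc(-n2c(-c3ccccc3)cn(C(C)=O)c2=O)cc(OC)c1OC`: > 50000 nM, a limit
Compound 2 `COc1cc(-n2c(-c3ccc([N+](=O)[O-])cc3)cn(C(C)=O)c2=O)cc(OC)c1OC`: 26600 nM
Compound 3 `COc1ccc(-c2cn(C(C)=O)c(=O)n2-c2cc(OC)c(OC)c(OC)c2)cc1`: 200 nM

All three values come from a functional assay on K562 cells (Homo sapiens) for cytotoxicity, read by MTT assay, with a stated time of 48 h; a lower number here means a stronger inhibitor, a higher number a weaker inhibitor. The value of compound 1 is a limit, as noted in the limit of > 50000 nM in this assay, at which 1 of the 3 values shown sits. Compound 3 holds the lowest number in the set, with a 130-fold lower number from compound 2 to compound 3 (2.12 log units; beyond the scatter). Compound 4 `COc1cc(-n2c(-c3ccc(F)cc3F)cn(C(C)=O)c2=O)cc(OC)c1OC` has 2,4-difluorophenyl in place of 4-methoxyphenyl on an aromatic carbon.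

The measured steps all change this same aryl group. Two are large: an at least 250-fold lower number from compound 1 to compound 3 (2.39 log units; beyond the scatter) and a 130-fold lower number from compound 2 to compound 3 (2.12 log units; beyond the scatter). The third, an at least 1.8-fold lower number from compound 1 to compound 2 (0.27 log units; that floor lies within the scatter), has a floor within the scatter. Both large steps go to the methoxy compound, and compound 4 gives up that methoxy, so a clear move to a higher number is expected in this assay. Within the data shown here, no measured compound carries fluorine, so the size of the move is uncertain. The expected change is a 25-fold higher number from compound 3 to compound 4 (1.40 log units; beyond the scatter). Compound 4 is estimated at 5000 nM, with an expected range from 600 nM to 40000 nM.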

Compound 4, half-maximal inhibitory concentration: > 50000 nM
Compound 4 gave a limit, no number; the forecaster's own chance of this, stated with the estimate: 15%; middle value at least 10-fold (1.00 log units) away from the limit.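

Among these compounds, at this aromatic carbon, next to the ring nitrogen, 2,4-difluorophenyl does not stand in for 4-methoxyphenyl in this assay: the swap gives an at least 250-fold higher number from compound 3 to compound 4 (2.39 log units; beyond the scatter), which leaves compound 3 as the only compound of the four with a low number. Against 4-nitrophenyl the change gives an at least 1.8-fold higher number from compound 2 to compound 4 (0.27 log units; that floor lies within the scatter), so no order can be stated between those two aryl groups. Compound 4 gives a limit, not a number, and the step between it and compound 1 cannot be read, with both compounds sitting at the same limit: the limit of > 50000 nM in this assay, at which 2 of the 4 values shown sit.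

Whether the low number of compound 3 is tied to methoxy itself stays open, since an ethoxy, a hydroxy or an amine on the phenyl ring does not appear among these compounds. From the compounds shown here alone, how far compound 4 lies beyond its limit also stays open.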